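Lengthening the hydrazide side chain of compound 1

This account rests on a few compounds, and the source may have more. Where it says the series, first, only, none or still open, it means among the compounds named here.

Compound 1 `NNC(=O)CN1C(=O)c2ccccc2NC1c1ccccc1` is tested in an assay on mitochondria for inhibition of Amine oxidase [flavin-containing] B (Bos taurus), read by fluorescence, with a stated time of 60 min (on this read-out lower numbers stand for stronger inhibition and higher numbers for weaker inhibition), where compound 1 gives 310000 nM. Going by the values given here, of the two compounds measured so far it has the lowest number; the only neighbour, compound 2 `COc1ccc(C2Nc3ccccc3C(=O)N2CC(=O)NN)cc1`, gives 890000 nM in this assay, a difference that is described as a 2.9-fold higher number from compound 1 to compound 2 (0.46 log units; beyond the scatter) for the change of methoxy in place of hydrogen on an aromatic carbon. Compound 3 `NNC(=O)CCN1C(=O)c2ccccc2NC1c1ccccc1` is not yet measured. It differs from compound 1 by (aminocarbamoyl)methyl in place of aminocarbamoyl on a saturated chain carbon bound to an amide-type nitrogen in a ring; cut one bond further out, the same difference reads (aminocarbamoyl)methyl to 2-(aminocarbamoyl)ethyl. Among the compounds with values here, no measured step touches this chain: the step from compound 1 to compound 2 concerns the aromatic ring only and so does not bear on it. Lacking any relevant step, one expects compound 3 to sit close to compound 1 in this assay, with a step of a 1.1-fold higher number from compound 1 to compound 3 (0.05 log units; within the scatter) that stays within the scatter. The estimate for compound 3 is therefore 350000 nM, with a range from 120000 nM to 1000000 nM.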

Compound 3, half-maximal inhibitory concentration: 210000 nM
Estimate against measurement, compound 3: 1.7-fold (0.22 log units) above, within the range that was stated.
By their numbers in this assay, from the lowest: compounds 3 and 1 (each within the scatter of the next); then compound 2.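

In this assay, going by these compounds alone, the step from (aminocarbamoyl)methyl to 2-(aminocarbamoyl)ethyl gives a 1.5-fold lower number from compound 1 to compound 3 (0.17 log units; within the scatter), the first reading of any kind on this chain. On a saturated chain carbon bound to an amide-type nitrogen in a ring, the added carbon therefore leaves the two compounds indistinguishable, so this position accepts the 2-(aminocarbamoyl)ethyl chain with the aminocarbamoyl end kept. No evidence is available that would explain this result.

From the compounds shown here alone, whether a longer chain, or a carboxylic acid or an amine in place of the aminocarbamoyl end, would move the number beyond the scatter remains open. Going by these compounds, it is also open whether methoxy on the aromatic ring, which gave a 2.9-fold higher number from compound 1 to compound 2 (0.46 log units; beyond the scatter) with the shorter chain, would act the same way with the 2-(aminocarbamoyl)ethyl chain.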